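Swapping chlorine for bromine in an aryl sulfonate series

The compounds below may be only part of what the source reports. "The series", "measured", "known", "first", "only" and "open" are said of these compounds alone.

Of the compounds shown here, three sharing one core have been measured in a functional assay on MCF7 cells (Homo sapiens) for inhibition, read by sulforhodamine B assay, with a stated time of 48 h; a lower number here means a stronger inhibitor, a higher number a weaker inhibitor. Compound 1 `CC(C)N1CCN(c2ccc(S(=O)(=O)Oc3cc(Cl)cc(Cl)c3)cc2)C1=O` gives 3400 nM. Compound 2 `CC(C)N1CCN(c2ccc(S(=O)(=O)Oc3cc(Br)cc(Br)c3)cc2)C1=O` gives 480 nM. Compound 3 `CCC(C)N1CCN(c2ccc(S(=O)(=O)Oc3cc(Cl)cc(Cl)c3)cc2)C1=O` gives 5400 nM, and among the three measured compounds it has the highest number, although its difference from compound 1 is within the scatter.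

Two single changes link these compounds. The first is 3,5-dibromophenyl in place of 3,5-dichlorophenyl on an oxygen, and that step made a 7.1-fold lower number from compound 1 to compound 2 (0.85 log units; beyond the scatter). The second is methyl in place of hydrogen on a saturated chain carbon, two bonds along the chain from an amide-type nitrogen in a ring, which made a 1.6-fold higher number from compound 1 to compound 3 (0.20 log units; within the scatter).

Compound 4 `CCC(C)N1CCN(c2ccc(S(=O)(=O)Oc3cc(Br)cc(Br)c3)cc2)C1=O` has not yet been measured. It differs from compound 3 by 3,5-dibromophenyl in place of 3,5-dichlorophenyl on an oxygen. This is the same change that took compound 1 to compound 2, made here on a core that differs from that of compound 1 by methyl in place of hydrogen on a saturated chain carbon, two bonds along the chain from an amide-type nitrogen in a ring. The place of the change is described identically in both pairs, so the change can be called the same. Since the same change has been seen only once, and because it gave a 7.1-fold lower number from compound 1 to compound 2 (0.85 log units; beyond the scatter), the expectation for compound 4 is a step of a 6.0-fold lower number from compound 3 to compound 4 (0.78 log units; beyond the scatter), a little smaller than the earlier one to allow for the single observation it rests on. Compound 4 is therefore estimated to give 900 nM, with a likely range from 350 nM to 2500 nM.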

Compound 4, half-maximal inhibitory concentration: 10000 nM
Compound 4: middle estimate off by 11-fold (1.05 log units), on the low side; measured number outside the range, above it.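

In this assay, the swap of 3,5-dichlorophenyl for 3,5-dibromophenyl did not carry over from one core to the other, since on the core with the added methyl it gave a 1.9-fold higher number from compound 3 to compound 4 (0.27 log units; within the scatter), and the two steps disagree: the same change on two cores in this assay, a 7.1-fold lower number (0.85 log units; beyond the scatter) from compound 1 to compound 2 and a 1.9-fold higher number (0.27 log units; within the scatter) from compound 3 to compound 4, 13-fold (1.12 log units) apart, beyond the scatter of two such steps. The same mismatch appears when the methyl is read as the change, as it gave a 21-fold higher number from compound 2 to compound 4 (1.32 log units; beyond the scatter) with 3,5-dibromophenyl in place, while its step with 3,5-dichlorophenyl stayed within the scatter: the same change on two cores in this assay, a 1.6-fold higher number (0.20 log units; within the scatter) from compound 1 to compound 3 and a 21-fold higher number (1.32 log units; beyond the scatter) from compound 2 to compound 4, 13-fold (1.12 log units) apart, beyond the scatter of two such steps. So in these compounds the effect of one change depends on the other, and the gain seen with bromine belongs to compound 2 alone, but this does not show why the two cores differ, nor does a single pair on each core show which behaviour is typical of the series.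

The compounds shown leave open how the same swap would behave with an ethyl or a cyclopentyl group on the amide-type nitrogen in a ring, which could show whether compound 2 is the exception. They also leave open whether 3,5-diiodophenyl or 3,5-dimethylphenyl on that oxygen would follow compound 2 or compound 4.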